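The compounds below may be only part of what the source reports. "The series", "measured", "known", "first", "only" and "open" are said of these compounds alone.

In an assay on isolated protein for agonist activity at Bile acid receptor (Homo sapiens), read by FRET (on this read-out higher numbers stand for an effect only at larger amounts of compound and lower numbers for an effect already at smaller amounts), compound 1 `O=C(O)c1cccc(C2CC2c2ccc(OCc3c(-c4c(Cl)cccc4Cl)noc3C3CC3)cc2Cl)c1` gives 32 nM, and compound 2 `O=C(O)c1cncc(C2CC2c2ccc(OCc3c(-c4c(Cl)cccc4Cl)noc3C3CC3)cc2Cl)c1` gives 10 nM, the lowest of the two numbers; the step of a 3.2-fold lower number from compound 1 to compound 2 (0.51 log units; beyond the scatter) separates them. Compound 3 `O=C(O)c1cccc([C@@H]2C[C@H]2c2ccc(OCc3c(-c4c(Cl)cccc4Cl)noc3C3CC3)cc2Cl)c1` carries 2-(3-carboxyphenyl)cyclopropyl in place of 2-(5-carboxypyridin-3-yl)cyclopropyl on an aromatic carbon, which is the reverse of that single measured step, with two defined stereocentres now fixed. Going by the values given here, the one step that bears on it is a 3.2-fold lower number from compound 1 to compound 2 (0.51 log units; beyond the scatter), so a modest move in the opposite direction is expected in this assay, a 2.5-fold higher number from compound 2 to compound 3 (0.40 log units; beyond the scatter). The estimate for compound 3 in this assay is 25 nM, with a range from 10 nM to 60 nM.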

Compound 3, half-maximal effective concentration: 18 nM
The estimate for compound 3 lay 1.4-fold (0.14 log units) above the measured number; measured number inside the range.
By their numbers in this assay, from the lowest: compounds 2, 3 and 1 (each within the scatter of the next, the first and the last beyond it).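

In this assay, the carboxyphenyl and carboxypyridinyl groups no longer stand clearly apart once the cyclopropyl stereocentres are defined: a 1.8-fold higher number from compound 2 to compound 3 (0.26 log units; within the scatter). The stereo comparison also stays inside the scatter: a 1.8-fold lower number from compound 1 to compound 3 (0.25 log units; within the scatter). That step cannot be tied to one configuration, and what limits its reading is this: the fact that one of compounds 1 and 3 is drawn with a defined configuration and the other without, at the place where they differ

The compounds shown leave open how the opposite cyclopropyl configuration behaves and what the 5-carboxypyridin-3-yl group gives with both stereocentres defined. They also leave open whether a tetrazole or a primary amide could stand in place of the carboxylic acid.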